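A pyridin-3-yl in place of the dimethylaminophenyl group

A few compounds are considered here, and "the series" means these few. Any claim that something is new, unique, unknown or untested is made for them only; others in the source may bear on it.

Measured so far:
compound 1, `COc1ccc(/C=N/NC(=O)c2cccnc2Nc2cccc(C(F)(F)F)c2)c(OC)c1`, in a functional assay on the whole organism (strain Wistar) for inhibition, with Rattus norvegicus as the target, read by paw edema, with a stated time of 30 min, at a dose of 10 mg/kg by the intraperitoneal route (a higher number here means more inhibition at the dose given (going by the name of the read-out), a lower number less inhibition), compound 1 gives 37.8%
compound 2, `CN(C)c1ccc(/C=N/NC(=O)c2cccnc2Nc2cccc(C(F)(F)F)c2)cc1`, in this assay compound 2 gives 61.3%

For the measured compounds named here, compound 2 stands highest of the two numbers in this assay; its only neighbour is compound 1, and the step of a number 23.5 percentage points higher from compound 1 to compound 2 (beyond the scatter) lies beyond the scatter. Compound 3, `O=C(N/N=C/c1cccnc1)c1cccnc1Nc1cccc(C(F)(F)F)c1`, is not yet measured. It differs from compound 2 in one place: pyridin-3-yl in place of 4-(dimethylamino)phenyl on a carbon with a double bond to nitrogen. Going by the values given here, the only measured step that bears on this is a number 23.5 percentage points higher from compound 1 to compound 2 (beyond the scatter), a change of the same ring on the same carbon, which shows that this position moves the read-out by a modest amount. Among the compounds with values here, no measured pair shows the pyridin-3-yl itself. The step of a number 16.3 percentage points lower from compound 2 to compound 3 (beyond the scatter) is therefore expected to be a modest decrease, possibly beyond the scatter. In this assay compound 3 is estimated at 45%, with a range from 25% to 65%.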

Compound 3, a percentage reported as inhibition, in the whole organism at one dose (the size of the read-out at that dose, not a potency): 59.1%
Beside the measured number, compound 3's estimate is 14.1 percentage points below it, and the stated range covers the measured number.
By their numbers in this assay, from the lowest: compound 1; then compounds 3 and 2 (each within the scatter of the next).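

In this assay, the pyridin-3-yl ring matches the 4-(dimethylamino)phenyl ring, with a number 2.2 percentage points lower from compound 2 to compound 3 (within the scatter) despite the drop from 9 to 6 heavy atoms, so the dimethylamino group and the larger ring are not needed for this level of response. The second comparison, a number 21.3 percentage points higher from compound 1 to compound 3 (beyond the scatter), shows that a replacement unlike the 4-(dimethylamino)phenyl ring also clears 2,4-dimethoxyphenyl, which leaves that group as the one that stands apart among these three. Nothing available here explains why these groups read as they do.

It remains open whether the ring nitrogen matters at all, since neither an unsubstituted phenyl nor a pyridin-4-yl ring appears among these compounds. How a single methoxy group or a carboxylic acid on the ring would read is also unknown.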